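The compounds below may be only part of what the source reports. "The series", "measured", "known", "first", "only" and "open" are said of these compounds alone.

Of the compounds shown here, three have been read in an ADME assay on HEK293 cells (Homo sapiens) for inhibition, read by MTT assay, with stated times of 18 h and 4 h; a lower number here means a stronger inhibitor, a higher number a weaker inhibitor. Compound 3 (`CCCCCCOP(=O)(O)OCCSC(=S)N1CCCCC1`) gives > 100000 nM, which is a limit and not a number. Compound 1 (`CCCCCCCCCCCCCCCCOP(=O)(O)OCCSC(=S)N1CCCCCC1`) gives > 100000 nM, which is also a limit. Within the data shown here, compound 2 (`CCCCCCCCCCOP(=O)(O)OCCSC(=S)N1CCCCC1`) is the only one with a number, 70700 nM. The measured set is thus marked by the limit of > 100000 nM in this assay, at which 2 of the 3 values shown sit.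

Compound 4 (`CCCCCCCCCCCCCCCCOP(=O)(O)OCCSC(=S)N1CCCCC1`) differs from compound 3 by one change: decyl in place of hydrogen on a saturated chain carbon, six bonds along the chain from an oxygen on an unsaturated carbon. Among the measured compounds shown here, one measured step bears on this change, an at least 1.4-fold higher number from compound 2 to compound 3 (0.15 log units; that floor lies within the scatter). It shortens the chain, whereas compound 4 lengthens it, and its size is only a floor, so it gives no firm measure. A modest fall in the number is therefore expected in this assay, with compound 2 at 70700 nM as the nearest guide. A reading at the limit remains quite possible for compound 4. The expected change is an at least 1.4-fold lower number from compound 3 to compound 4 (0.15 log units; that floor lies within the scatter). For compound 4 the estimated value is 70000 nM, with an expected range from 25000 nM to 150000 nM.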

Compound 4, half-maximal inhibitory concentration: > 100000 nM
Compound 4: no number, only a limit; the forecaster's own chance of this, stated with the estimate: 50%; middle value at least 1.4-fold (0.15 log units) away from the limit.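

Adding hexyl to the chain gives, in this assay, an at least 1.4-fold higher number from compound 2 to compound 4 (0.15 log units; that floor lies within the scatter), so this further lengthening shows no sign of a lower number. Among these compounds, compound 4 gives > 100000 nM, which is a limit, and compound 2 stays the only compound here with a number. The steps to compound 4 from compound 3 and from compound 1 cannot be read, and the series remains marked by one ceiling: the limit of > 100000 nM in this assay, at which 3 of the 4 values shown sit.

Going by these compounds, whether an octyl or a dodecyl chain on the shared core would give a number in this assay stays open, and so does the true size of any difference around compound 2. Also open, on these data alone, is whether an amine or a carboxylic acid at the far end of the chain would change the reading.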